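Undoing the Benzyl on the Lactam Nitrogen

This account rests on a few compounds, and the source may have more. Where it says the series, first, only, none or still open, it means among the compounds named here.

Three measured compounds share one core and differ at the saturated chain carbon bound to the amide-type nitrogen in the ring. Compound 1 `Cc1ccc2c(c1)C1(C(=O)N2C)C(C#N)=C(N)Oc2cc3oc(-c4ccccc4)cc(=O)c3c(O)c21` carries methyl there, and in a functional assay on K562 cells (Homo sapiens) for antiproliferative activity, read by MTT assay, with a stated time of 48 h (a lower number here means a stronger inhibitor, a higher number a weaker inhibitor), compound 1 gives 5870 nM. Compound 2 `Cc1ccc2c(c1)C1(C(=O)N2Cc2ccccc2)C(C#N)=C(N)Oc2cc3oc(-c4ccccc4)cc(=O)c3c(O)c21` carries benzyl there. For compound 2 the assay reports only a limit, > 50000 nM. The step of an at least 8.5-fold higher number from compound 1 to compound 2 (0.93 log units; beyond the scatter) is the one that bears on the present question. Compound 3 `N#CC1=C(N)Oc2cc3oc(-c4ccccc4)cc(=O)c3c(O)c2C12C(=O)N(Cc1ccccc1)c1ccc(Cl)cc12` gives 36300 nM in this assay, and the step of an at least 1.3-fold lower number from compound 2 to compound 3 (0.13 log units; that floor lies within the scatter) concerns chloro in place of methyl on an aromatic carbon, so it says little about the nitrogen substituent.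

Compound 4 `CCN1C(=O)C2(C(C#N)=C(N)Oc3cc4oc(-c5ccccc5)cc(=O)c4c(O)c32)c2cc(C)ccc21` is not yet measured. It differs from compound 2 by methyl in place of phenyl on a saturated chain carbon bound to an amide-type nitrogen in a ring. This largely reverses the change that turned compound 1 into compound 2, so a lower number is expected in this assay, back toward compound 1. Because compound 2 sits at the limit of > 50000 nM in this assay, at which 1 of the 3 values shown sits, the true size of the return cannot be fixed from the data. Compound 4 is expected to give 9000 nM, within 3000 nM to 30000 nM. The expected step of an at least 5.5-fold lower number from compound 2 to compound 4 (0.74 log units; beyond the scatter) is therefore a clear fall beyond the scatter.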

Compound 4, half-maximal inhibitory concentration: > 50000 nM
Compound 4 gave a limit, no number; the forecaster's own chance of this, stated with the estimate: 15%; middle value at least 5.5-fold (0.74 log units) from the limit.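

The result moves the loss from the phenyl to something much smaller. Methyl in place of hydrogen on the saturated chain carbon bound to the amide-type nitrogen in the ring gives an at least 8.5-fold higher number from compound 1 to compound 4 (0.93 log units; beyond the scatter), so, in this pair, the phenyl of the benzyl group is not needed for a fall in activity beyond the scatter. Compound 2 and compound 4 now both stand as limits, and the step between them cannot be read: the limit of > 50000 nM in this assay, at which 2 of the 4 values shown sit.

On these data alone, the true values of compound 2 and compound 4 remain open, and so it is unknown whether ethyl and benzyl truly differ at this position. Also open, as far as these compounds go, is what an amine or a carboxylic acid on this saturated chain carbon would give in this assay.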